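Thiosemicarbazone Series: Removing the 4-Methylphenyl Group

A few compounds are considered here, and "the series" means these few. Any claim that something is new, unique, unknown or untested is made for them only; others in the source may bear on it.

Measured so far in a functional assay on L1210 cells (Mus musculus) for inhibition, read by cell counting, with a stated time of 48 h; a lower number here means a stronger inhibitor, a higher number a weaker inhibitor:
- Compound 1, `CCN(CC)CN1C(=O)/C(=N/NC(N)=S)c2cc(Cl)ccc21`, gives 148000 nM.
- Compound 2, `CCN(CC)CN1C(=O)/C(=N/NC(=S)Nc2ccc(C)cc2)c2ccccc21`, gives 29000 nM.
- Compound 3, `CCN(CC)CN1C(=O)/C(=N/NC(=S)Nc2ccc(C)cc2)c2cc(Cl)ccc21`, gives 9500 nM.

Compound 4, `CCN(CC)CN1C(=O)/C(=N/NC(N)=S)c2ccccc21`, has not yet been measured in this assay. It differs from compound 2 in one place: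

hydrogen in place of 4-methylphenyl on an amide-type nitrogen

The same change has already been measured once, from compound 3 to compound 1:

hydrogen in place of 4-methylphenyl on an amide-type nitrogen

That step produced a 16-fold higher number from compound 3 to compound 1 (1.19 log units; beyond the scatter), a large move toward weaker inhibition. The two place descriptions agree word for word, so this is the same change on a different core. The cores of compound 2 and compound 3 differ as follows:

hydrogen in place of chloro on an aromatic carbon

Between those two cores the step is a 3.1-fold lower number from compound 2 to compound 3 (0.48 log units; beyond the scatter). Among the compounds with values here, compound 2 thus sits in the middle of the three measured numbers, and only one pair bears on the change at the thiourea nitrogen.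

Within the data shown here, for compound 4 the expectation is a step of a 16-fold higher number from compound 2 to compound 4 (1.19 log units; beyond the scatter) from compound 2, taken to match the earlier step, because a 16-fold higher number from compound 3 to compound 1 (1.19 log units; beyond the scatter) is the only measurement of this change and nothing among the three compounds suggests the cores respond differently to it. With that, compound 4 is estimated at 450000 nM in this assay. Among the measured compounds shown here, the expected range for compound 4 runs from 150000 nM to 1200000 nM, wide because a 16-fold higher number from compound 3 to compound 1 (1.19 log units; beyond the scatter) is the single measured pair on which the transfer rests.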

Compound 4, half-maximal inhibitory concentration: 121000 nM
The estimate for compound 4 lay 3.7-fold (0.57 log units) above the measured number; measured number below the stated range.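

In this assay, the change from (4-methylphenyl)amino to amino gives a 4.2-fold higher number from compound 2 to compound 4 (0.62 log units; beyond the scatter), so the direction of the earlier step holds on the second core, but its size does not: the same change on two cores in this assay, a 16-fold higher number (1.19 log units; beyond the scatter) from compound 3 to compound 1 and a 4.2-fold higher number (0.62 log units; beyond the scatter) from compound 2 to compound 4, 3.7-fold (0.57 log units) apart, beyond the scatter of two such steps

Hydrogen in place of chloro on an aromatic carbon gives a 1.2-fold lower number from compound 1 to compound 4 (0.09 log units; within the scatter) in the pair ending in amino, so those two values cannot be told apart, whereas the same exchange in the pair carrying 4-methylphenyl lies beyond the scatter: the same change on two cores in this assay, a 3.1-fold lower number (0.48 log units; beyond the scatter) from compound 2 to compound 3 and a 1.2-fold higher number (0.09 log units; within the scatter) from compound 4 to compound 1, 3.7-fold (0.57 log units) apart, beyond the scatter of two such steps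

These four compounds form a single closed set, so the two gaps are one finding seen from two sides: the 4-methylphenyl and chloro changes do not combine independently here, and a step size measured on one core did not hold on the other, though the set shows neither what lies behind this nor how any further core would respond.

Still open, on these data alone, is whether the step depends on the 4-methylphenyl group specifically or on any group at the amide-type nitrogen, which a plain phenyl or a short alkyl chain there would help to separate. Also open, as far as these compounds go, is whether the same dependence appears with bromo or fluoro in place of chloro on that aromatic carbon.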